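The source may report more compounds than this note shows. Statements on the series, on what has been measured and on what is new or still open speak of the compounds shown alone.

Of the compounds shown here, three built on one shared core have been tested in an assay on isolated protein for inhibition of 2-Hydroxyacid oxidase 2 (Homo sapiens), tested at 10 uM; on this read-out lower numbers stand for a weaker effect and higher numbers for a stronger effect at the one concentration tested. Compound 1 `Cc1n[nH]c(C(=O)O)c1Cc1cccc(-c2ccc(C(N)=O)cc2)c1` gives 60%, the highest of the three. Compound 2 `Cc1n[nH]c(C(=O)O)c1Cc1cccc(C(N)=O)c1` gives 8%, and compound 3 `Cc1n[nH]c(C(=O)O)c1Cc1cccc(C(F)(F)F)c1` gives 23%. The difference between them is a single change, (trifluoromethyl in place of carbamoyl on an aromatic carbon), and this change produced a number 15 percentage points higher from compound 2 to compound 3 (beyond the scatter). How the core of compound 1 differs from that of compound 2 is not broken down here. Compound 4 `Cc1n[nH]c(C(=O)O)c1Cc1cccc(-c2ccc(C(F)(F)F)cc2)c1` has not yet been measured. It carries the same kind of change on compound 1, (trifluoromethyl in place of carbamoyl on an aromatic carbon), but its place is para to a large group, whereas in compound 3 the place is meta to a large group. Because a number 15 percentage points higher from compound 2 to compound 3 (beyond the scatter), a modest rise is expected in this assay, namely a number 10 percentage points higher from compound 1 to compound 4 (within the scatter). Compound 4 is therefore estimated at 70%, between 52% and 86%.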

Compound 4, a percentage reported as inhibition, at one concentration (the size of the read-out at that concentration, not a potency): 30%
For compound 4 the middle estimate is 40 percentage points above the measured one; measured number outside the range, below it.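

Putting trifluoromethyl in place of carbamoyl gives a number 30 percentage points lower from compound 1 to compound 4 (beyond the scatter) in this assay. This change therefore cannot simply be carried from one core to another in this series, since its effect differs between the two cores and even reverses in direction: the same change on two cores in this assay, a number 15 percentage points higher (beyond the scatter) from compound 2 to compound 3 and a number 30 percentage points lower (beyond the scatter) from compound 1 to compound 4, 45 percentage points apart, beyond the scatter of two such steps. What this does not show is why the two steps differ, and two pairs of compounds cannot predict the outcome on any further core.

As far as these compounds go, it remains open whether another group in the place of carbamoyl on compound 1, such as an amine, a carboxylic acid or a nitrile, would keep its number or lower it. Each compound was read at a single concentration, and the numbers speak only of a stronger or weaker effect at that concentration.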